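The source may report more compounds than this note shows. Statements on the series, on what has been measured and on what is new or still open speak of the compounds shown alone.

Compound 3 `C[C@]1(CN2CCc3nc(-c4cc(F)ccc4F)ccc3C2)Cn2cc([N+](=O)[O-])nc2O1` stands at a limit in an ADME assay on Vero cells (Chlorocebus sabaeus) for cytotoxicity, read by MTT assay, with a stated time of 72 h (on this read-out lower numbers stand for higher toxicity in this test and higher numbers for lower toxicity in this test), rather than at a number: in this assay compound 3 gives > 32 ug/mL. Compound 1 `C[C@]1(CN2CCc3nc(-c4ccccc4F)ccc3C2)Cn2cc([N+](=O)[O-])nc2O1` likewise reaches only a limit, and in this assay compound 1 gives > 32 ug/mL. Compound 2 `C[C@]1(CN2CCc3nc(-c4ccc(Cl)cc4)ccc3C2)Cn2cc([N+](=O)[O-])nc2O1` carries no result in this assay, entered as "not determined" (no result reported). Among the compounds with values here, the single step between measured compounds, a step that the two limits leave unreadable from compound 1 to compound 3, cannot be read because both ends sit on (the limit of > 32 ug/mL in this assay, at which 2 of the 3 values shown sit). Compound 4 `C[C@]1(CN2CCc3nc(-c4cc(Cl)ccc4F)ccc3C2)Cn2cc([N+](=O)[O-])nc2O1` differs from compound 3 by chloro in place of fluoro on an aromatic carbon. Within the data shown here, no readable measured step bears on this change: the one step between measured compounds is hidden behind the two limits, and compound 2 adds no number. The expectation for compound 4 can therefore rest on nothing more than the two limits already seen. Compound 4 is estimated to sit around 40 ug/mL in this assay, between 20 ug/mL and 80 ug/mL, and most likely to be reported again as a limit. The step expected for this change, a step that the limit leaves unreadable from compound 3 to compound 4, is taken as no larger than the scatter.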

Compound 4, half-maximal cytotoxic concentration: > 32 ug/mL
Compound 4: a limit, no number (the forecaster's own chance of this, stated with the estimate: 80%); the middle value does not contradict the limit.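

In this assay compound 4, like compound 1 and compound 3, reaches only a limit, so no new step can be read among these compounds: the limit of > 32 ug/mL in this assay, at which 3 of the 4 values shown sit.

The compounds shown leave open how far each value lies past that limit, and whether chloro in place of fluoro changes it at all.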